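The source may hold more compounds than are shown below. What is called first, only, known or untested is meant among the compounds shown, and "the series" means these compounds.

Measured so far in a functional assay on NCI/ADR-RES cells (Homo sapiens) for cytotoxicity, read by sulforhodamine B assay, with a stated time of 48 h, tested at 10 uM; on this read-out higher numbers stand for a weaker effect at the one concentration tested and lower numbers for a stronger effect:
Compound 1, `COc1cc(-c2cc(/C=C/C(=O)c3ccc(N)cc3)[nH]n2)cc(OC)c1OC`, gives 15%.
Compound 2, `COc1ccc(C(=O)/C=C/c2cc(-c3cc(OC)c(OC)c(OC)c3)n[nH]2)cc1OC`, gives 10%.

Both numbers are low, so both compounds cut the growth of these cells strongly at the single concentration tested. Among the measured compounds shown here, compound 2 holds the lower of the two numbers, but its only neighbour, compound 1, sits close by: the step of a number 5 percentage points lower from compound 1 to compound 2 (within the scatter) lies within the scatter, so the two compounds cannot be told apart on these numbers.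

Compound 3, `COc1cc(-c2cc(/C=C/C(=O)c3ccc(F)c(F)c3)[nH]n2)cc(OC)c1OC`, is not yet measured. It differs from compound 2 in one place: 3,4-difluorophenyl in place of 3,4-dimethoxyphenyl on a carbonyl carbon. For the measured compounds named here, the one measured step that bears on this change is the earlier exchange of the group on a carbonyl carbon, a number 5 percentage points lower from compound 1 to compound 2 (within the scatter), which showed nothing beyond the scatter. On that basis no step beyond the scatter is expected in this assay for compound 3 either, and the expected step is a number 4 percentage points higher from compound 2 to compound 3 (within the scatter). Compound 3 is therefore estimated at 14%, with a range from 4% to 40%. A single supporting step is a thin basis, so the range is kept wide.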

Compound 3, a percentage reported as activity, at one concentration (the size of the read-out at that concentration, not a potency): 11%
Compound 3: the middle estimate sits 3 percentage points above what was measured, and the stated range covers the measured number.
By their numbers in this assay, from the lowest: compounds 2, 3 and 1 (each within the scatter of the next).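

In this assay the step of a number 1 percentage points higher from compound 2 to compound 3 (within the scatter) shows that 3,4-difluorophenyl can stand on the carbonyl carbon in place of 3,4-dimethoxyphenyl with no difference that can be read. This holds even though the group that enters has 0 hydrogen-bond acceptors and 8 heavy atoms, where the group that leaves has 2 acceptors and 10 heavy atoms. The step of a number 4 percentage points lower from compound 1 to compound 3 (within the scatter) gives the same reading for 3,4-difluorophenyl against 4-aminophenyl, so the three groups at this place cannot be told apart, and the strong effect seen here is not tied to any one of them. Nothing measured here says why the numbers stay together at this place.

On these data alone, all three numbers are readings at a single concentration, so it stays open whether these compounds would separate at lower concentrations. Also open, as far as these compounds go, is whether a group of a different kind on the carbonyl carbon, such as a carboxylic acid, a plain methyl in place of the ring, or a longer chain, would keep the effect this strong.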